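The compounds below may be only part of what the source reports. "The series", "measured", "known", "first", "only" and "open" are said of these compounds alone.

In a functional assay on HepG2 cells (Homo sapiens) for antiproliferative activity, read by XTT assay, with a stated time of 72 h (a higher number here means a weaker inhibitor, a lower number a stronger inhibitor), three compounds have been read so far. Compound 1 (`Cc1ncnc2c1c(-c1ccoc1)cn2[C@@H]1O[C@H](CO)[C@@H](O)[C@H]1O`) gives 5320 nM and compound 2 (`Cc1ncnc2c1c(-c1ccsc1)cn2[C@@H]1O[C@H](CO)[C@@H](O)[C@H]1O`) gives 4720 nM in this assay and the two are separated only by a 1.1-fold lower number from compound 1 to compound 2 (0.05 log units; within the scatter) and so stand level. Compound 3 (`CNc1ncnc2c1c(I)cn2[C@@H]1O[C@H](CO)[C@@H](O)[C@H]1O`) returns no number, only the limit > 20000 nM of the assay.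

Compound 4 (`Cc1ncnc2c1c(I)cn2[C@@H]1O[C@H](CO)[C@@H](O)[C@H]1O`) keeps the iodine of compound 3 and changes one group, with methyl in place of methylamino on an aromatic carbon. Among the compounds with values here, no measured step covers this change directly. Within the data shown here, the single step available concerns furan-3-yl and thiophen-3-yl, elsewhere on the molecule, and it stays within the scatter. What bears on compound 4 is indirect: compound 1 and compound 2 carry the same methyl, though with those rings where compound 4 has iodine. Among the measured compounds shown here, with compound 1 at 5320 nM and compound 2 at 4720 nM as the only guide, a step towards a lower number, meaning a stronger inhibitor, is expected, beyond the scatter but of uncertain size. The expected change is an at least 3.3-fold lower number from compound 3 to compound 4 (0.52 log units; beyond the scatter) as estimated here. Compound 4 is expected near 6000 nM with an estimated range from 1500 nM to 20000 nM in this assay.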

Compound 4, half-maximal inhibitory concentration: 3460 nM
Compound 4: middle estimate off by 1.7-fold (0.24 log units), on the high side; the measured number falls inside the stated range.
By their numbers in this assay, from the lowest: compounds 4, 2 and 1 (each within the scatter of the next). At a limit, above all of these: compound 3.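

In this assay, within the data shown here, with the iodine held fixed, methyl in place of methylamino on an aromatic carbon of the six-membered aromatic ring gives an at least 5.7-fold lower number from compound 3 to compound 4 (0.76 log units; beyond the scatter), the first step at this position that lies beyond the scatter, whereas the earlier compounds showed only a step within it, at another place on the molecule. The full size of this step cannot be read, as compound 3 gives a limit and not a number: the limit of > 20000 nM in this assay, at which 1 of the 4 values shown sits. With the methyl held fixed, iodo now joins the two rings, with a 1.4-fold lower number from compound 2 to compound 4 (0.13 log units; within the scatter) and a 1.5-fold lower number from compound 1 to compound 4 (0.19 log units; within the scatter), so that in this small set the group at that other place shifts the number by no more than the scatter, while the change at the methyl position does.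

The compounds shown leave open whether methylamino would cost as much alongside furan-3-yl or thiophen-3-yl as it does alongside iodine. They also leave open how a primary amine, a methoxy group or a longer chain such as ethyl would read in this position on the shared core.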